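The compounds below may be only part of what the source reports. "The series", "measured", "known", "first", "only" and "open" are said of these compounds alone.

Measured so far:
Compound 1, `O=c1c(CSC(=S)N2CCCC2)coc2ccccc12` — 6000 nM
Compound 2, `COc1ccc2occ(CSC(=S)N3CCOCC3)c(=O)c2c1` — limit > 40000 nM
Compound 3, `CN1CCN(C(=S)SCc2coc3ccccc3c2=O)CC1` — 17600 nM

Three compounds share one core and differ in the amine on the thiocarbonyl carbon. In a functional assay on LM7 cells (Homo sapiens) for antiproliferative activity, read by MTT assay, with a stated time of 72 h (on this read-out lower numbers stand for stronger inhibition and higher numbers for weaker inhibition), compound 1 gives 6000 nM. Compound 3 gives 17600 nM in this assay, the highest of the two numbers shown. For compound 2, whose core also carries a methoxy group, this assay returns only a limit, > 40000 nM; it is a limit and not a number, and the evidence notes (the limit of > 40000 nM in this assay, at which 1 of the 3 values shown sits).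

Compound 4 is `O=c1c(CSC(=S)N2CCOCC2)coc2ccccc12`. It arises from compound 3 by morpholin-4-yl in place of 4-methylpiperazin-1-yl on a thiocarbonyl carbon. Within the data shown here, the one measured step at this position is a 2.9-fold higher number from compound 1 to compound 3 (0.47 log units; beyond the scatter). It shows that the choice of amine on the thiocarbonyl carbon moves the number by a modest amount beyond the scatter. Compound 2, which carries the same morpholin-4-yl group on a methoxy-bearing core, sits at a limit, which is not a number and does not give a step to compound 4.

Compound 4 is therefore expected to sit at or somewhat above compound 3, with a step of a 1.7-fold higher number from compound 3 to compound 4 (0.23 log units; within the scatter). The estimate for compound 4 in this assay is 30000 nM, with a range from 12000 nM to 80000 nM.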

Compound 4, half-maximal inhibitory concentration: 12000 nM
Beside the measured number, compound 4's estimate is 2.5-fold (0.40 log units) above it; low and high end bracket the measured number.
By their numbers in this assay, from the lowest: compounds 1, 4 and 3 (each within the scatter of the next, the first and the last beyond it). At a limit, above all of these: compound 2.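

In this assay, morpholin-4-yl on the thiocarbonyl carbon cannot be told apart from either of the other two amines: the result is a 1.5-fold lower number from compound 3 to compound 4 (0.17 log units; within the scatter) and a 2.0-fold higher number from compound 1 to compound 4 (0.30 log units; within the scatter). The amine series therefore reads as a shallow spread, with compound 4 within the scatter of both neighbours, and only its two ends separated, by a 2.9-fold higher number from compound 1 to compound 3 (0.47 log units; beyond the scatter). The result also gives the first step in which the amine stays fixed and the core changes: hydrogen in place of methoxy on an aromatic carbon gives an at least 3.3-fold lower number from compound 2 to compound 4 (0.52 log units; beyond the scatter), which lies beyond the scatter, and the value of compound 2 behind that step is a limit and not a number: the limit of > 40000 nM in this assay, at which 1 of the 4 values shown sits.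

The compounds shown leave open where an open-chain amine such as diethylamino, or a piperidin-1-yl ring, would fall on the thiocarbonyl carbon. They also leave open whether the methoxy step holds with pyrrolidin-1-yl or 4-methylpiperazin-1-yl as the amine, and what a chlorine in place of methoxy on that aromatic carbon would do.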